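Cytotoxicity notes on the triazole-linked oxadiazole series

The source may report more compounds than this note shows. Statements on the series, on what has been measured and on what is new or still open speak of the compounds shown alone.

Of the compounds shown here, three have been measured in an ADME assay on RAW264.7 cells (Mus musculus) for cytotoxicity, read by MTT assay, with a stated time of 48 h; a lower number here means that less compound is tolerated, a higher number that more compound is tolerated. Compound 1 `CC(=O)OC[C@H]1O[C@H](OC[C@H](Cn2cc(COc3ccc(-c4noc(C)n4)cc3)nn2)OC(C)=O)C=C[C@@H]1OC(C)=O` gives 112 ug/mL. Compound 2 `C#Cc1ccc(-c2noc(NC3CCCCC3)n2)cc1` gives 19.8 ug/mL. Compound 3 `CC(=O)OC[C@H]1O[C@H](OC[C@@H](Cn2cc(CN(c3nc(-c4ccc(Cl)cc4)no3)C3CCCCC3)nn2)OC(C)=O)C=C[C@@H]1OC(C)=O` gives 35.5 ug/mL, the second highest of the three numbers; its gap to compound 2 lies within the scatter, while its gap to compound 1 is beyond the scatter, compound 1 being tolerated at the higher concentration.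

Compound 4 `COc1ccc(-c2noc(N(Cc3cn(C[C@H](CO[C@@H]4C=C[C@H](OC(C)=O)[C@@H](COC(C)=O)O4)OC(C)=O)nn3)C3CCCCC3)n2)cc1` has not been measured. It differs from compound 3 in one place, methoxy in place of chloro on an aromatic carbon, the aryl ring reading 4-methoxyphenyl instead of 4-chlorophenyl. Within the data shown here, no measured pair in this set isolates that change, so there is no precedent to draw on. The expectation is a step of no more than the scatter in this assay, with a slight lean toward a higher tolerated concentration, so that the estimated step runs a 1.2-fold higher number from compound 3 to compound 4 (0.07 log units; within the scatter). Compound 4 is therefore expected to give about 42 ug/mL, within a range of 20 ug/mL to 90 ug/mL.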

Compound 4, half-maximal cytotoxic concentration: 86.3 ug/mL
Compound 4: the middle estimate sits 2.1-fold (0.31 log units) below what was measured, and the stated range covers the measured number.
By their numbers in this assay, from the lowest: compounds 2 and 3 (each within the scatter of the next); then compounds 4 and 1 (each within the scatter of the next).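

In this assay, among these compounds, the change from 4-chlorophenyl to 4-methoxyphenyl gives a 2.4-fold higher number from compound 3 to compound 4 (0.39 log units; beyond the scatter), the only step so far that isolates a single place. With the rest of compound 3 held fixed, the group on this aromatic carbon is enough on its own to shift the tolerated concentration, and the methoxy compound is the better tolerated of the pair. No measurement at hand bears on the reason for this step.

Going by these compounds, this change is read on one pair only, so it remains open whether the same step would appear with a different group on the other side of the shared core. Also open, on these data alone, is how an amine, a carboxylic acid or a longer alkoxy chain on this aromatic carbon would compare with chloro and methoxy.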